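Swapping the Outer Aryl Group in a Bile Acid Receptor Series

This account rests on a few compounds, and the source may have more. Where it says the series, first, only, none or still open, it means among the compounds named here.

Measured so far:
compound 1, `COC(=O)/C=C/c1cccc(N(Cc2ccc(/C=C/C(=O)O)cc2)C(=O)C2CCCCC2)c1`, gives 1000 nM
compound 2, `COC(=O)/C=C/c1cccc(N(Cc2ccc(-c3cccc(Cl)c3)cc2)C(=O)NC(C)C)c1`, gives 1410 nM

Both numbers come from an assay on isolated protein with Bile acid receptor (Homo sapiens) as the target; a lower number here means that less compound is needed, a higher number that more compound is needed for the effect. Compound 2 and compound 1 lie within the usual scatter of each other, so neither can be called the more potent. Compound 3, `COC(=O)/C=C/c1cccc(N(Cc2ccc(-c3c(OC)cccc3OC)cc2)C(=O)NC(C)C)c1`, differs from compound 2 by 2,6-dimethoxyphenyl in place of 3-chlorophenyl on an aromatic carbon. For the measured compounds named here, no measured pair shows what such a swap does, so no step beyond the scatter is expected in either direction; the change from compound 2 to compound 3 is expected to be a 1.3-fold higher number from compound 2 to compound 3 (0.11 log units; within the scatter). Compound 3 is therefore expected to give about 1800 nM, within 600 nM to 5500 nM.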

Compound 3, half-maximal effective concentration: 562 nM
Compound 3: middle estimate off by 3.2-fold (0.51 log units), on the high side; measured number below the stated range.
By their numbers in this assay, from the lowest: compounds 3, 1 and 2 (each within the scatter of the next, the first and the last beyond it).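

In this assay, for the compounds shown here, the swap of 3-chlorophenyl for 2,6-dimethoxyphenyl brings a 2.5-fold lower number from compound 2 to compound 3 (0.40 log units; beyond the scatter) and is the first single change here to move the number beyond the scatter. The position para to a large group therefore responds to the aryl group it carries, and it tolerates the larger group with its 2 hydrogen-bond acceptors. Nothing available here accounts for the step.

Going by these compounds, whether the gain comes from adding the methoxy groups or from losing the chlorine stays open. A plain phenyl or a phenyl with a single methoxy group at this place would help separate the two.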